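A few compounds are considered here, and "the series" means these few. Any claim that something is new, unique, unknown or untested is made for them only; others in the source may bear on it.

Of the compounds shown here, three built on a shared core have been measured so far in a physicochemical assay for solubility, read by HPLC, in phosphate buffer, measured as kinetic solubility, at pH 7.4 (a lower number here means a less soluble compound, a higher number a more soluble compound), and they span a modest range. Compound 1 `CCC(=O)c1ccn(-c2ccc(S(N)(=O)=O)cc2)c1C` gives 100000 nM while compound 2 `CCC(=O)c1cc(-c2ccc(F)cc2)n(-c2ccc(S(N)(=O)=O)cc2)c1C` gives 29300 nM and compound 3 `CCC(=O)c1cc(-c2cccc(Cl)c2)n(-c2ccc(S(N)(=O)=O)cc2)c1C` gives 12600 nM in the same measurement. Compound 2 is thus the second highest of the three numbers.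

The next compound to be read is compound 4 `Cc1c(C(=O)O)cc(-c2ccc(F)cc2)n1-c1ccc(S(N)(=O)=O)cc1` and it differs from compound 2 in one place. The change is hydroxy in place of ethyl on a carbonyl carbon and, cut one bond further out, it reads propanoyl to carboxy.

Within the data shown here, no measured step touches this place, so the evidence is only indirect. Putting 4-fluorophenyl in place of hydrogen on an aromatic carbon gave a 3.4-fold lower number from compound 1 to compound 2 (0.53 log units; beyond the scatter) and putting 3-chlorophenyl there gave a 7.9-fold lower number from compound 1 to compound 3 (0.90 log units; beyond the scatter) while exchanging the two groups gave a 2.3-fold lower number from compound 2 to compound 3 (0.37 log units; beyond the scatter) as the smallest of the three. All three steps are modest and beyond the scatter, and they suggest the size of a plausible move rather than its direction. The direction rests on the structural change alone, and a modest step towards a higher number is expected in this assay for this change.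

The expected change is a 2.7-fold higher number from compound 2 to compound 4 (0.44 log units; beyond the scatter) in this estimate. Compound 4 is estimated at 80000 nM with an expected range from 30000 nM to 180000 nM in this assay once it is measured.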

Compound 4, solubility: 50000 nM
Compound 4: middle estimate off by 1.6-fold (0.20 log units), on the high side; measured number inside the range.
By their numbers in this assay, from the lowest: compound 3; then compounds 2, 4 and 1 (each within the scatter of the next, the first and the last beyond it).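

Among these compounds, this is the first measured change at the carbonyl carbon, as every earlier step changed a group on an aromatic carbon. In this assay, among the compounds shown here, hydroxy in place of ethyl gives a 1.7-fold higher number from compound 2 to compound 4 (0.23 log units; within the scatter), so this exchange of a two-carbon ethyl for a single-oxygen hydroxy cannot be told apart from repeat-to-repeat variation, unlike the earlier steps, which were all beyond the scatter. The compounds shown offer no measured property that would account for this result.

For the compounds shown here, this single pair covers only two groups at the carbonyl carbon and only one setting, with 4-fluorophenyl on the aromatic carbon, so it cannot show whether other groups there, such as an amine forming an amide, a methoxy group forming an ester, or a longer chain in place of ethyl, would also stay within the scatter. It also leaves open whether the same change from propanoyl to carboxy would give a similar step on the core of compound 1, which carries hydrogen at that aromatic carbon, or on compound 3, which carries 3-chlorophenyl there.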